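The source may report more compounds than this note shows. Statements on the series, on what has been measured and on what is new or still open speak of the compounds shown alone.

Measured in a functional assay on DU-145 cells (Homo sapiens) for antiproliferative activity, read by WST assay, with a stated time of 3 days; on this read-out higher numbers stand for weaker inhibition and lower numbers for stronger inhibition:
- Compound 1 `CCCCCCOc1c(-c2cc(OC)c(OC)c(OC)c2)oc2ccccc2c1=O`: > 50000 nM
- Compound 2 `COc1cc(-c2oc3ccccc3c(=O)c2OC(C)C)cc(OC)c1OC`: > 50000 nM
- Compound 3 `CCCN(CCC)CCCOc1c(-c2cc(OC)c(OC)c(OC)c2)oc2ccccc2c1=O`: > 50000 nM

Each entry is a limit and not a number. Compound 3 therefore has no exact place on the scale, only its limit of > 50000 nM. The whole set looks the same: the limit of > 50000 nM in this assay, at which 3 of the 3 values shown sit.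

Compound 4 `CCCCCN(CCCCC)CCCCOc1c(-c2cc(OC)c(OC)c(OC)c2)oc2ccccc2c1=O` differs from compound 3 in one place: (dipentylamino)methyl in place of dipropylamino on a saturated chain carbon, three bonds along the chain from an oxygen on an aromatic ring. Here (dipentylamino)methyl stands in place of dipropylamino, on a saturated chain carbon, three bonds along the chain from an oxygen on an aromatic ring.

Two measured steps change this same part of the molecule: a step that the two limits leave unreadable from compound 1 to compound 3 and a step that the two limits leave unreadable from compound 2 to compound 3. Neither has a size that can be read, and the same holds for a step that the two limits leave unreadable from compound 1 to compound 2. They offer no firm size or direction for the new change in this assay, so another limit is the likeliest result. The expected change is small and uncertain: an at least 1.1-fold lower number from compound 3 to compound 4 (0.04 log units; that floor lies within the scatter). For compound 4 the estimated value is 45000 nM, with an expected range of 10000 nM to 100000 nM.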

Compound 4, half-maximal inhibitory concentration: 12500 nM
Compound 4: middle estimate off by 3.6-fold (0.56 log units), on the high side; the measured number falls inside the stated range.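

In this assay, (dipentylamino)methyl in place of dipropylamino gives an at least 4.0-fold lower number from compound 3 to compound 4 (0.60 log units; beyond the scatter), and the comparison with the hexyl compound gives an at least 4.0-fold lower number from compound 1 to compound 4 (0.60 log units; beyond the scatter). Going by these compounds alone, both sizes are floors, and the steps among compounds 1, 2 and 3 cannot be read, so this is the first sign that the group on this oxygen can move the read-out into a measurable range. A nitrogen in the chain is not enough by itself, since compound 3 also carries one and still shows no exact value, as the rest of the set shows: the limit of > 50000 nM in this assay, at which 3 of the 4 values shown sit.

On these data alone, the change lengthens both the chain and the groups on the nitrogen, so the share of each remains open. Also open, as far as these compounds go, is how a ring amine such as piperidine, or a longer chain still, would fare at this position.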